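Growing the Piperazine Tail on a Weakly Cytotoxic Core

The source may hold more compounds than are shown below. What is called first, only, known or untested is meant among the compounds shown, and "the series" means these compounds.

Compound 1 `Cn1c(-c2ccc(NC(=O)CSc3nc4cc(Cl)ccc4o3)cc2)nc(-c2ccccc2)c1-c1ccccc1`: 2.5%
Compound 2 `CN1CCN(CC(=O)Nc2ccc(-c3nc(-c4ccccc4)c(-c4ccccc4)n3C)cc2)CC1`: 2.9%

Among the measured compounds shown here, in a functional assay on MCF7 cells (Homo sapiens) for cytotoxicity, read by MTT assay, with a stated time of 24 h, tested at 1.6 ug/mL (a higher number here means a stronger effect of the compound at the concentration tested, a lower number a weaker effect), compound 2 stands highest of the two numbers, yet its only neighbour is compound 1, and the step of a number 0.4 percentage points higher from compound 1 to compound 2 (within the scatter) lies within the scatter. Compound 3 `CN(C)/C=C/N1CCN(CC(=O)Nc2ccc(-c3nc(-c4ccccc4)c(-c4ccccc4)n3C)cc2)CC1` has not been measured. It differs from compound 2 in one place: 2-(dimethylamino)ethenyl in place of methyl on an amine nitrogen in a ring. For the measured compounds named here, the single measured step concerned a group on a saturated chain carbon, not the ring nitrogen, so it bears only loosely here; both measured values are low. I therefore expect no step beyond the scatter, a number 1.1 percentage points higher from compound 2 to compound 3 (within the scatter). Compound 3 is estimated at 4%, ranging from 0% to 15%.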

Compound 3, a percentage reported as activity, at one concentration (the size of the read-out at that concentration, not a potency): 1.9%
For compound 3 the middle estimate is 2.1 percentage points above the measured one, and the stated range covers the measured number.
By their numbers in this assay, from the lowest: compounds 3, 1 and 2 (each within the scatter of the next).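

In this assay, this is the only step shown at the amine nitrogen of the piperazine ring: exchanging methyl for the larger 2-(dimethylamino)ethenyl gives a number 1 percentage points lower from compound 2 to compound 3 (within the scatter). Even a change of the whole tail gives a number 0.6 percentage points lower from compound 1 to compound 3 (within the scatter), so across these compounds neither change moves the read-out beyond the scatter. No measurement here explains this flat result.

Still open, on these data alone, is whether a carboxylic acid or a longer chain ending in an amine on that ring nitrogen would change the read-out. As far as these compounds go, whether any group at this position can raise it beyond the scatter also remains unknown.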